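Swapping a substituted benzyl for a pyridylmethyl group

This account rests on a few compounds, and the source may have more. Where it says the series, first, only, none or still open, it means among the compounds named here.

Measured compounds:
compound 1, `Cc1c(C2CC2)nc2ccc(-n3ccc(OCc4ccc(Br)cc4)cc3=O)cn12`: 12 nM
compound 2, `Cc1c(C2CC2)nc2ccc(-n3ccc(OCc4ccc(C(C)C)cc4)cc3=O)cn12`: 410 nM

In an assay on CHO cells for displacement of a labelled ligand from melanin-concentrating hormone receptor 1 (Homo sapiens), read by scintillation counting, with a stated time of 1 h (a lower number here means a stronger inhibitor, a higher number a weaker inhibitor), compound 2 gives the higher of the two numbers. Within the data shown here, the one measured step, a 34-fold higher number from compound 1 to compound 2 (1.53 log units; beyond the scatter), shows how much the group carried on the saturated chain carbon bound to the oxygen matters. Compound 3, `Cc1c(C2CC2)nc2ccc(-n3ccc(OCc4cccnc4)cc3=O)cn12`, changes that same part: pyridin-3-yl in place of 4-isopropylphenyl on a saturated chain carbon bound to an oxygen on an aromatic ring. Among the measured compounds shown here, no measured step covers a pyridin-3-yl group there, so the isopropyl-to-bromo comparison is the only guide. Because the step of a 34-fold higher number from compound 1 to compound 2 (1.53 log units; beyond the scatter) was large, removing the isopropyl-bearing ring is expected to lower the number, estimated as a 3.4-fold lower number from compound 2 to compound 3 (0.53 log units; beyond the scatter). Compound 3 is therefore expected to give about 120 nM, within 25 nM to 600 nM.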

Compound 3, half-maximal inhibitory concentration: > 1000 nM
Compound 3: no number, only a limit; the forecaster's own chance of this, stated with the estimate: 5%; middle value at least 8.3-fold (0.92 log units) away from the limit.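

Compound 3 has no exact number, only a limit: the limit of > 1000 nM in this assay, at which 1 of the 3 values shown sits.
Losing the isopropyl-bearing ring does not recover binding: the pyridin-3-yl group gives an at least 2.4-fold higher number from compound 2 to compound 3 (0.38 log units; beyond the scatter) and also an at least 83-fold higher number from compound 1 to compound 3 (1.92 log units; beyond the scatter).
At this position, then, even the weaker 4-isopropylphenyl group outperforms pyridin-3-yl.

Pyridin-3-yl brings a ring nitrogen and also lacks any ring substituent, so these two changes cannot be told apart here. An unsubstituted phenyl group at this position would separate them.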